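Ester to primary amide on the shared core

The compounds below may be only part of what the source reports. "The series", "measured", "known", "first", "only" and "open" are said of these compounds alone.

Measured compounds:
compound 1 `CC1=C(C(=O)OC(C)(C)C)C(c2cccs2)NC(=O)N1` 38%
compound 2 `CC1=C(C(=O)OC(C)(C)C)C(c2ccsc2)NC(=O)N1` 47%

Compound 2 shows the higher of the two numbers in an assay on membranes from HEK293 cells for displacement of a labelled ligand from adenosine receptor A2b (Homo sapiens), read by scintillation counting, with a stated time of 30 min, tested at 1 uM (a lower number here means less inhibition, a higher number more inhibition at the concentration tested (going by the name of the read-out)), with compound 1 at 38% and the step of a number 9 percentage points higher from compound 1 to compound 2 (within the scatter) within the scatter. Compound 3 `CC1=C(C(N)=O)C(c2ccsc2)NC(=O)N1` differs from compound 2 by amino in place of tert-butoxy on a carbonyl carbon. For the measured compounds named here, no measured step touches the carbonyl carbon; the only measured step concerns the thiophene, so nothing here speaks to this change. Compound 3 is therefore expected near compound 2, with a wide range, a number 7 percentage points lower from compound 2 to compound 3 (within the scatter). The estimate for compound 3 is 40%, spanning 10% to 70%.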

Compound 3, a percentage reported as inhibition, at one concentration (the size of the read-out at that concentration, not a potency): 1%
Estimate against measurement, compound 3: 39 percentage points above; the measured number lies below the stated range.
By their numbers in this assay, from the lowest: compound 3; then compounds 1 and 2 (each within the scatter of the next).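

Unlike the thiophene change, where a number 9 percentage points higher from compound 1 to compound 2 (within the scatter), the group on the carbonyl carbon has a large effect in this assay: a number 46 percentage points lower from compound 2 to compound 3 (beyond the scatter). On the thiophen-3-yl compounds, tert-butoxy therefore cannot be exchanged for amino without losing almost all the inhibition seen at the concentration tested. No available evidence accounts for this loss.

Still open, on these data alone, is whether a smaller ester such as methoxy or ethoxy, a carboxylic acid or a methylamino amide on this carbonyl carbon would keep the number of compound 2. Also open, as far as these compounds go, is how amino behaves with thiophen-2-yl in place of thiophen-3-yl.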